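This account rests on a few compounds, and the source may have more. Where it says the series, first, only, none or still open, it means among the compounds named here.

In a functional assay on MSTO-211H cells (Homo sapiens) for inhibition, read by trypan blue exclusion, with a stated time of 72 h (a higher number here means a weaker inhibitor of growth, a lower number a stronger inhibitor of growth), compound 1 (`Cc1ncsc1C(=O)Oc1ccc(-c2[nH]c3ccccc3c2C)cc1`) stands at > 20000 nM as a limit of the assay, not a number. Compound 2 (`Cc1c(-c2ccc(O)c(O)c2)n(CCCCOc2ccccc2)c2ccc(O)cc12`) gives 3400 nM and compound 3 (`COc1ccc2c(c1)c(C)c(-c1ccc(OC)c(OC)c1)n2CCCCOc1ccccc1`) gives 13000 nM in the same test, but both differ widely in structure from compound 1. Compound 4 (`Cc1c(-c2ccc(OC(=O)c3c[nH]cn3)cc2)[nH]c2ccccc12`) keeps the core of compound 1 but has 1H-imidazol-4-yl in place of 4-methyl-1,3-thiazol-5-yl on a carbonyl carbon. Among the measured compounds shown here, no measured pair tests this exchange directly. The expected shift, an at least 1.6-fold lower number from compound 1 to compound 4 (0.22 log units; that floor lies within the scatter) in this assay, is small and toward stronger inhibition of growth, and it may not exceed the scatter. For compound 4 the estimated value is 12000 nM within an expected range of 4000 nM to 30000 nM in this test.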

Compound 4, concentration for 50% growth inhibition: > 20000 nM
Compound 4: only a limit was reported; the forecaster's own chance of this, stated with the estimate: 45%; middle value at least 1.6-fold (0.22 log units) away from the limit.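

Among the compounds shown here, compound 1 and compound 4 both stand at a limit of the assay, not a number, so no step between them can be read: the limit of > 20000 nM in this assay, at which 2 of the 4 values shown sit. In this assay the compounds shown leave open whether 1H-imidazol-4-yl in place of 4-methyl-1,3-thiazol-5-yl changes growth inhibition at all.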